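The source may hold more compounds than are shown below. What is called first, only, known or untested is meant among the compounds shown, and "the series" means these compounds.

Measured compounds:
compound 1 `COc1cc(-c2nn(-c3cccc(NC(=O)Nc4cc(C(F)(F)F)cc(C(F)(F)F)c4)c3)cc2-c2ccncc2)ccc1Cl` — 694 nM
compound 2 `COc1cc(-c2nn(-c3cccc(NC(=O)c4cccc(C(F)(F)F)c4)c3)cc2-c2ccncc2)ccc1Cl` — 978 nM

Both were tested in a functional assay on SK-MEL-5 cells (Homo sapiens) for inhibition, read by sulforhodamine B assay, with a stated time of 48 h; a lower number here means a stronger inhibitor of growth, a higher number a weaker inhibitor of growth. Compound 2 stands at the higher of the two numbers, with compound 1 nearest, and the two values lie within the scatter of each other, so no order between them can be read.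

Compound 3 `COc1cc(-c2nn(-c3cccc(NC(=O)Nc4ccc(Cl)c(Cl)c4)c3)cc2-c2ccncc2)ccc1Cl` is not yet measured. It differs from compound 2 in one place: (3,4-dichlorophenyl)amino in place of 3-(trifluoromethyl)phenyl on a carbonyl carbon. Within the data shown here, no step between measured compounds is recorded for this exchange, so the expectation rests only on the two values shown. Compound 1 also carries a carbamoyl linkage and in this assay gives 694 nM, which does not part from compound 2. Compound 3 is therefore expected to show a step of a 1.4-fold lower number from compound 2 to compound 3 (0.15 log units; within the scatter), not beyond the scatter. Compound 3 is estimated at 700 nM, with a range from 300 nM to 1600 nM.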

Compound 3, concentration for 50% growth inhibition: 741 nM
Estimate against measurement, compound 3: 1.1-fold (0.02 log units) below, within the range that was stated.
By their numbers in this assay, from the lowest: compounds 1, 3 and 2 (each within the scatter of the next).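

In this assay, placing (3,4-dichlorophenyl)amino on the carbonyl carbon in place of 3-(trifluoromethyl)phenyl gives a 1.3-fold lower number from compound 2 to compound 3 (0.12 log units; within the scatter) and so does not part the two compounds. This single step shows that changing (3-(trifluoromethyl)phenyl)carbonyl to (3,4-dichlorophenyl)carbamoyl, which brings in a hydrogen-bond donor, leaves no readable change in this read-out. Nothing measured here bears on the reason for this result.

The compounds shown leave open whether a piperidine or a short alkyl chain in place of the aromatic ring on this carbonyl carbon would stay within the scatter or move the number beyond it. They also leave open whether any exchange at this place, including a carboxylic acid or a primary amine on the aromatic ring, can separate compounds in this assay at all.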